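The compounds below may be only part of what the source reports. "The series", "measured", "known", "first", "only" and "open" are said of these compounds alone.

Compound 1, `CCCC#Cc1cc([C@@H]2O[C@H](CO)[C@@H](O)[C@H]2O)n2ncnc(N)c12`: 200 nM in a functional assay on HCT-116 cells (Homo sapiens) for antiproliferative activity, with a stated time of 72 h; a higher number here means a weaker inhibitor, a lower number a stronger inhibitor.
Compound 2, `Nc1ncnn2c([C@@H]3O[C@H](CO)[C@@H](O)[C@H]3O)cc(-c3ccccc3F)c12`: in this assay compound 2 reaches only a limit of the assay, > 100000 nM.

Compound 2 thus stands at the weak end of what the assay can report; its value is a limit rather than a number, and the limit of > 100000 nM in this assay, at which 1 of the 2 values shown sits, tells where it sits. Within the data shown here, the one measured step is an at least 500-fold higher number from compound 1 to compound 2 (2.69 log units; beyond the scatter), the change being 2-fluorophenyl in place of pent-1-yn-1-yl on an aromatic carbon. Compound 3, `Cc1ccccc1-c1cc([C@@H]2O[C@H](CO)[C@@H](O)[C@H]2O)n2ncnc(N)c12`, is not yet measured. It differs from compound 2 by methyl in place of fluoro on an aromatic carbon. Among the measured compounds shown here, no measured step swaps fluoro for methyl, so the measured step bears on it only indirectly: both compound 2 and compound 3 carry a six-membered aromatic ring of carbon only where compound 1 carries the pent-1-yn-1-yl group, and it was the arrival of that ring that went with the large loss of potency. Compound 3 is therefore expected to stay near the limit, with a step of about a number no higher from compound 2 to compound 3 (the limit leaves the size open) expected, meaning no change beyond the scatter. For compound 3 the estimate in this assay is 100000 nM, ranging from 20000 nM to 300000 nM, and the assay is expected most likely to report only a limit again.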

Compound 3, half-maximal inhibitory concentration: > 100000 nM
Compound 3: only a limit was reported; the forecaster's own chance of this, stated with the estimate: 70%; the middle value lies on the limit itself.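

The large loss of potency is not specific to the fluoro group: 2-methylphenyl in place of pent-1-yn-1-yl also gives an at least 500-fold higher number from compound 1 to compound 3 (2.69 log units; beyond the scatter) in this assay. Compound 3 is reported only as a limit, and it now shares that limit with compound 2: the limit of > 100000 nM in this assay, at which 2 of the 3 values shown sit. The step from fluoro to methyl cannot be read, as neither compound has an actual number, so any difference between these two groups on the ring remains hidden, but two different 2-substituted phenyl groups at this position now go with the same outcome.

The compounds shown leave open whether the loss extends to every ring at this position, such as an unsubstituted phenyl or a pyridine, or whether it is limited to phenyl rings that carry a group ortho to a large group. They also leave open how much of the potency of compound 1 depends on the triple bond or on the length of the chain, a question that a saturated pentyl chain or the shorter prop-1-yn-1-yl group would address.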